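Leaving methoxy on the benzyl group

The compounds below may be only part of what the source reports. "The series", "measured", "known", "first", "only" and "open" are said of these compounds alone.

Compound 1 `Cc1cc(Nc2ccn(Cc3ccc(F)cc3)n2)n2nc(SCc3ccc(Br)cc3)nc2n1`: 19400 nM
Compound 2 `COc1ccc(Cn2ccc(Nc3cc(C)nc4nc(SCc5ccc(Br)cc5)nn34)n2)cc1`: > 50000 nM (a limit of the assay)

In a functional assay on PC-9 cells (Homo sapiens) for inhibition, read by MTT assay, with a stated time of 72 h (a lower number here means a stronger inhibitor, a higher number a weaker inhibitor), compound 1 gives 19400 nM. Compound 2 has no number, only the limit > 50000 nM. Within the data shown here, one measured step bears on what follows: an at least 2.5-fold higher number from compound 1 to compound 2 (0.41 log units; beyond the scatter), with methoxy in place of fluoro on an aromatic carbon. Its size is known only as a bound.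

Compound 3 `Cc1cc(Nc2ccn(Cc3ccc(C(F)(F)F)cc3)n2)n2nc(SCc3ccc(Br)cc3)nc2n1` differs from compound 2 by trifluoromethyl in place of methoxy on an aromatic carbon, para to a large group. Among the measured compounds shown here, with only this step as a guide, removing the methoxy is expected to lower the number towards compound 1 at 19400 nM, though trifluoromethyl has not been tested here. A second limit remains possible. The expected change is an at least 2.2-fold lower number from compound 2 to compound 3 (0.35 log units; beyond the scatter). For compound 3 the estimated value is 22000 nM, with an expected range of 9000 nM to 50000 nM.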

Compound 3, half-maximal inhibitory concentration: 5580 nM
Compound 3: middle estimate off by 3.9-fold (0.60 log units), on the high side; measured number outside the range, below it.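

In this assay the 4-(trifluoromethyl)benzyl group of compound 3 gives the lowest number of the three, so the fluoro compound no longer marks the best result at this place. Against fluoro the change gives a 3.5-fold lower number from compound 1 to compound 3 (0.54 log units; beyond the scatter) and shows that this position can move the number downward as well as upward, which the earlier step did not show. Against methoxy it gives an at least 8.9-fold lower number from compound 2 to compound 3 (0.95 log units; beyond the scatter) and spans the widest gap seen at this place, yet that gap is only a bound because compound 2 carries a limit of the assay: the limit of > 50000 nM in this assay, at which 1 of the 3 values shown sits.

The compounds shown leave open whether the lower number is particular to trifluoromethyl or also holds for a nitrile or a pentafluoroethyl group at this place. They also leave open how an amine or a carboxylic acid there would read.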